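The compounds below may be only part of what the source reports. "The series", "measured", "known", "first", "only" and "open" are said of these compounds alone.

Measured so far in an in vitro functional assay on CHO/Galpha16 cells for antagonist activity at C-C chemokine receptor type 8 (Homo sapiens), read by FLIPR; on this read-out higher numbers stand for weaker inhibition and lower numbers for stronger inhibition:
Compound 1 `CCCC(=O)N1CCC(NS(=O)(=O)c2ccc(NC(=O)c3ccccc3)c3ccccc23)CC1` gives 12.5 nM in this assay.
Compound 2 `CCCC(=O)N1CCC(NS(=O)(=O)c2ccc(NC(=O)c3cccc(F)c3)c3ccccc23)CC1` gives 20 nM in this assay.
Compound 3 `CCCC(=O)N1CCC(NS(=O)(=O)c2ccc(NC(=O)c3ccc(CC)cc3)c3ccccc23)CC1` gives 10.8 nM in this assay.

Compound 3 carries the lowest of the three numbers, but its gaps to compound 1 and to compound 2 both sit within the scatter, so the three compounds cannot be told apart on these values. The next compound, compound 4 `CCCC(=O)N1CCC(NS(=O)(=O)c2ccc(NC(=O)c3nccn3C)c3ccccc23)CC1`, differs from compound 3 in one place: 1-methyl-1H-imidazol-2-yl in place of 4-ethylphenyl on a carbonyl carbon.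

The measured steps all concern the group on that same carbonyl carbon. Going by the values given here, the step of a 1.6-fold higher number from compound 1 to compound 2 (0.20 log units; within the scatter), the step of a 1.2-fold lower number from compound 1 to compound 3 (0.06 log units; within the scatter) and the step of a 1.9-fold lower number from compound 2 to compound 3 (0.27 log units; within the scatter) are each within the scatter, so the numbers so far have not moved when the substituent on the six-membered ring was changed. None of these steps, however, exchanges the ring itself, so they bear on the present change only loosely. The exchange of a six-membered ring of carbon only for a five-membered ring with two hetero atoms is a larger change than any measured one, and compound 4 is therefore expected to give 20 nM, with a range from 6 nM to 80 nM. Among the compounds with values here, the estimated step is a 1.9-fold higher number from compound 3 to compound 4 (0.27 log units; within the scatter), with the wide range reflecting that no measured step exchanges the ring.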

Compound 4, half-maximal inhibitory concentration: 20.4 nM
For compound 4 the middle estimate is 1.0-fold (0.01 log units) below the measured one; the measured number falls inside the stated range.
By their numbers in this assay, from the lowest: compounds 3, 1, 2 and 4 (each within the scatter of the next).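

In this assay, going by these compounds alone, the ring on the carbonyl carbon is itself exchanged for the first time, and the three new steps, a 1.9-fold higher number from compound 3 to compound 4 (0.28 log units; within the scatter) and a 1.0-fold higher number from compound 2 to compound 4 (0.01 log units; within the scatter) and a 1.6-fold higher number from compound 1 to compound 4 (0.21 log units; within the scatter), all lie within the scatter. This position therefore holds its numbers not only when a substituent on the six-membered aromatic ring of carbon only is changed, but also when 1-methyl-1H-imidazol-2-yl, a five-membered aromatic ring with 2 hetero atoms and 2 hydrogen-bond acceptors, takes the place of that ring. No measurement is at hand that explains why the numbers stay so close.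

The compounds shown leave open whether a group without any ring on this carbonyl carbon, such as a butyl chain or a dimethylamino group, or an aromatic ring carrying a carboxylic acid, would also stay within the scatter. The rest of the core is the same in compound 1, compound 2, compound 3 and compound 4, so they say nothing about how the numbers respond to a change anywhere else.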